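The source may report more compounds than this note shows. Statements on the series, on what has been measured and on what is new or still open speak of the compounds shown alone.

Measured compounds:
Compound 1, `O=C(Nc1cccc(-n2cc(-c3ccncc3)c(-c3ccc(Cl)c(O)c3)n2)c1)Nc1ccc(Cl)c(Cl)c1`, in a functional assay on IGROV-1 cells (Homo sapiens) for inhibition, read by sulforhodamine B assay, with a stated time of 48 h; a lower number here means a stronger inhibitor of growth, a higher number a weaker inhibitor of growth: > 32500 nM, a limit of the assay and not a number.
Compound 2, `COc1cc(-c2nn(-c3cccc(NC(=O)c4ccccc4)c3)cc2-c2ccncc2)ccc1Cl`, in this assay: > 100000 nM, likewise a limit and not a number.

Compound 1 thus stands at the limit of > 32500 nM in this assay, at which 1 of the 2 values shown sits. Compound 2 stands at the limit of > 100000 nM in this assay, at which 1 of the 2 values shown sits. Among the compounds with values here, neither gives a number, so the two values show only that both compounds sit at the edge of what the assay can report, and no step between them can be sized.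

Compound 3, `O=C(Nc1cccc(-n2cc(-c3ccncc3)c(-c3ccc(Cl)c(O)c3)n2)c1)Nc1ccc(Cl)c(C(F)(F)F)c1`, is not yet measured. It differs from compound 1 in one place: trifluoromethyl in place of chloro on an aromatic carbon. Within the data shown here, no measured pair shows an exchange of this kind, so there is nothing to size it against. Compound 1 stands only at a limit. The step that the limit leaves unreadable from compound 1 to compound 3 is expected to stay within the usual scatter, with a fair chance that compound 3 is again reported as a limit. Compound 3 is estimated at about 40000 nM, in a range from 15000 nM to 150000 nM.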

Compound 3, concentration for total growth inhibition: 2220 nM
Beside the measured number, compound 3's estimate is 18-fold (1.26 log units) above it, and the stated range ends above it.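

In this assay, placing trifluoromethyl instead of chloro on this aromatic carbon, ortho to a chloro group, has a large effect on the growth read-out (an at least 14-fold lower number from compound 1 to compound 3 (1.16 log units; beyond the scatter)). Within the data shown here, this is the first sign that this position on the 3,4-dichlorophenyl group matters, and compound 3 gives a real number (2220 nM), which the earlier compounds did not. Compound 1 sits at a limit and not at a number, so the step has no upper size and its full extent stays unknown: the limit of > 32500 nM in this assay, at which 1 of the 3 values shown sits.

The compounds shown leave open whether a nitrile, a methyl or a methoxy group on the same carbon would have a similar effect or whether this is special to trifluoromethyl. They also leave open what happens if the remaining chloro group is exchanged.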